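Fluoro in place of methyl in an A-375 antiproliferative series

The compounds below may be only part of what the source reports. "The series", "measured", "known", "first", "only" and "open" are said of these compounds alone.

Measured compounds:
compound 1, `O=C1COc2ccc(-c3cnc(Cl)c(NS(=O)(=O)c4ccc(F)cc4)c3)cc2N1c1ccc(F)cc1`: > 40000 nM
compound 2, `Cc1ccc(N2C(=O)COc3ccc(-c4cnc(Cl)c(NS(=O)(=O)c5ccc(F)cc5)c4)cc32)cc1`: 38900 nM
compound 3, `Cc1ccc(N2C(=O)COc3ccc(-c4cccc(NS(=O)(=O)c5ccc(F)cc5)c4)cc32)cc1`: 36200 nM

All three were read in a functional assay on A-375 cells (Homo sapiens) for antiproliferative activity, read by MTT assay, with a stated time of 72 h; a lower number here means a stronger inhibitor, a higher number a weaker inhibitor. For compound 1 the reading is a limit of the assay rather than a number, > 40000 nM; it sits at the limit of > 40000 nM in this assay, at which 1 of the 3 values shown sits. Compound 2 gives 38900 nM in this assay, and compound 3 gives 36200 nM. The two numbers lie within the usual scatter of each other, so no order between compound 2 and compound 3 is claimed.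

Compound 2 and compound 1 share a core and differ only in one change, (fluoro in place of methyl on an aromatic carbon). The measured step is an at least 1.0-fold higher number from compound 2 to compound 1 (0.01 log units; that floor lies within the scatter), and since compound 1 is reported only as a limit, the step can only be read as a floor.

Compound 3 and compound 2 share the same change of methyl-bearing aryl on the amide nitrogen but differ in their cores; that difference between the two cores is not broken down here.

Compound 4, `O=C1COc2ccc(-c3cccc(NS(=O)(=O)c4ccc(F)cc4)c3)cc2N1c1ccc(F)cc1`, stands to compound 3 as compound 1 stands to compound 2: the change is fluoro in place of methyl on an aromatic carbon, the same change as before, since both sit on an aromatic carbon para to a large group. The expected step from compound 3 to compound 4 is a 1.2-fold higher number from compound 3 to compound 4 (0.06 log units; within the scatter), resting on the measured at least 1.0-fold higher number from compound 2 to compound 1 (0.01 log units; that floor lies within the scatter) and on (the limit of > 40000 nM in this assay, at which 1 of the 3 values shown sits), which together suggest the reading may again come back as a limit. Compound 4 is therefore estimated at 42000 nM in this assay, between 25000 nM and 80000 nM.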

Compound 4, half-maximal inhibitory concentration: > 40000 nM
Compound 4 ended at the assay's limit; the forecaster's own chance of this, stated with the estimate: 60%; the middle value does not contradict the limit.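

In this assay, fluoro in place of methyl on an aromatic carbon, read here as 4-methylphenyl to 4-fluorophenyl, gives an at least 1.1-fold higher number from compound 3 to compound 4 (0.04 log units; that floor lies within the scatter). Compound 4 is reported only as a limit of the assay, so this step is a floor and not a size, and the comparison across the two cores has the same standing: the same change on two cores in this assay, an at least 1.0-fold higher number (0.01 log units; that floor lies within the scatter) from compound 2 to compound 1 and an at least 1.1-fold higher number (0.04 log units; that floor lies within the scatter) from compound 3 to compound 4; the limit leaves it open whether they differ. The two floors fit a change that carries from one core to the other without a step beyond the scatter, but they do not show that it carries with the same size, and much of this small set reads at the ceiling of the assay: the limit of > 40000 nM in this assay, at which 2 of the 4 values shown sit.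

Open, going by these compounds, is whether any group at this place on the aryl ring, such as an amine, a carboxylic acid or a longer chain in place of the methyl or fluoro, gives a number clearly clear of the limit. Also open is whether fluoro in place of methyl would give a step of readable size on a core whose readings lie well away from that limit, as the compounds shown offer no such case.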